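This account rests on a few compounds, and the source may have more. Where it says the series, first, only, none or still open, it means among the compounds named here.

The measured compounds:
compound 1, `CN(CCCN1CCCCC1)c1cccc(C(=O)N2CCc3ccc(OS(N)(=O)=O)cc3C2)c1`, which in an assay on HEK293 cells for inhibition of Steryl-sulfatase (Homo sapiens), tested at 1 uM (a higher number here means a stronger effect of the compound at the concentration tested, a lower number a weaker effect), gives 30.6%
compound 2, `CCCN(Cc1ccccc1)c1cccc(C(=O)N2CCc3ccc(OS(N)(=O)=O)cc3C2)c1`, which gives 67.4%

Compound 2 stands highest of the two numbers shown; its nearest neighbour, compound 1, lies below it by a gap beyond the scatter. For the measured compounds named here, the single measured step, a number 36.8 percentage points higher from compound 1 to compound 2 (beyond the scatter), came with benzyl(propyl)amino in place of methyl(3-(piperidin-1-yl)propyl)amino on an aromatic carbon. Compound 3, `CCN(Cc1cccnc1)c1cccc(C(=O)N2CCc3ccc(OS(N)(=O)=O)cc3C2)c1`, has not yet been measured. It differs from compound 2 in one place: ethyl((pyridin-3-yl)methyl)amino in place of benzyl(propyl)amino on an aromatic carbon. Going by the values given here, only the step from compound 1 to compound 2 bears on this change, and it is an indirect guide: it shows that an exchange at this position can move the read-out strongly, but it does not separate the part played by the propyl chain from that of the benzyl ring. Compound 3 keeps an aromatic ring on that nitrogen yet not the benzyl(propyl)amino that accompanied the high value of compound 2. A moderate fall in this assay is therefore expected for compound 3, a number 17.4 percentage points lower from compound 2 to compound 3 (beyond the scatter). The estimate for compound 3 is 50%, within a range from 22% to 78%.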

Compound 3, a percentage reported as inhibition, at one concentration (the size of the read-out at that concentration, not a potency): 33.5%
The estimate for compound 3 lay 16.5 percentage points above the measured number; the range from low to high includes it.
By their numbers in this assay, from the lowest: compounds 1 and 3 (each within the scatter of the next); then compound 2.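

In this assay the exchange gives a number 33.9 percentage points lower from compound 2 to compound 3 (beyond the scatter) with ethyl((pyridin-3-yl)methyl)amino in place of benzyl(propyl)amino, so an aromatic ring on that nitrogen does not by itself keep the high read-out of compound 2. The other new step, a number 2.9 percentage points higher from compound 1 to compound 3 (within the scatter) with ethyl((pyridin-3-yl)methyl)amino in place of methyl(3-(piperidin-1-yl)propyl)amino, shows that these two quite different groups cannot be told apart here, and that among the three groups at this position only benzyl(propyl)amino stands apart. Nothing at hand accounts for this difference.

The change from compound 2 to compound 3 alters two things at once, a six-membered aromatic ring of carbon only giving way to one with 1 hetero atom and propyl giving way to ethyl, so the compounds shown leave open which of these carries the step. Ethyl(benzyl)amino and propyl((pyridin-3-yl)methyl)amino would separate the two, and it also remains open how a butyl chain in place of propyl beside the benzyl group would read.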